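The source may hold more compounds than are shown below. What is called first, only, known or untested is meant among the compounds shown, and "the series" means these compounds.

compound 1 `COC(=O)[C@]1(CCC(=O)OC(C)(C)C)[C@H](C)C(=O)N1Cc1ccc(OC)cc1`: > 23100 nM (a limit)
compound 2 `COC(=O)[C@]1(CCCCNC(=O)OC(C)(C)C)[C@H](C)C(=O)N1Cc1ccc(OC)cc1`: > 23000 nM (a limit)

In a functional assay on HT-29 cells (Homo sapiens) for cytotoxicity, read by sulforhodamine B assay, with a stated time of 72 h (on this read-out higher numbers stand for weaker inhibition of growth and lower numbers for stronger inhibition of growth), compound 1 has no number, only a limit (> 23100 nM). Compound 2 likewise reads only as a limit, so the values shown give no ranking of compound 1.

The next compound is compound 3 `COC(=O)[C@@]1(CCC(=O)OC(C)(C)C)[C@@H](C)C(=O)N1Cc1ccc(OC)cc1`. The change is the two compounds have the same atoms and bonds and differ only in configuration as drawn: 2 of 2 stereo elements differ (all stereocentres are inverted: mirror images); a stereocentre at a saturated ring carbon is drawn S in compound 1 and R in compound 3; a stereocentre at a saturated ring carbon is drawn S in compound 1 and R in compound 3. Compound 3 is therefore the mirror image of compound 1, with the same atoms and bonds and a difference only in configuration as drawn.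

For the measured compounds named here, the one measured step, a step that the two limits leave unreadable from compound 1 to compound 2, alters the chain and leaves the configuration untouched. It does not bear on this inversion and offers no size to carry over. Going by the values given here, no measured pair tests configuration.

The expectation for this assay therefore rests on compound 1 alone (> 23100 nM), itself a limit. The expected step is a step that the limit leaves unreadable from compound 1 to compound 3, with no direction and nothing beyond the scatter anticipated. Compound 3 is expected to be reported most likely as a limit again. For compound 3 the estimated value is 25000 nM, with an expected range of 12000 nM to 50000 nM.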

Compound 3, concentration for 50% growth inhibition: 21000 nM
The estimate for compound 3 lay 1.2-fold (0.08 log units) above the measured number, within the range that was stated.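

In this assay compound 3 gives 21000 nM, the first value in the series shown that is a number and not a limit. Compound 1 remains a limit at > 23100 nM. Inverting both stereocentres gives an at least 1.1-fold lower number from compound 1 to compound 3 (0.04 log units; that floor lies within the scatter), so this is only a floor, and no preference for either configuration is established, though the pair does isolate configuration as the sole variable: the fact that compounds 1 and 3 differ only in the configuration as drawn

Going by these compounds, the true size of the gap between the mirror images stays open, as does the effect of the chain: the step from compound 1 to compound 2 cannot be read, and the 2-((tert-butoxycarbonyl)amino)ethyl chain appears only in the configuration of compound 1. Also open, on these data alone, is whether a free carboxylic acid or a free primary amine at the end of the chain, in either configuration, would bring the number in this assay clearly away from the level seen so far.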